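The source may report more compounds than this note shows. Statements on the series, on what has been measured and on what is new or still open speak of the compounds shown alone.

Going by the values given here, compound 1 `Cn1cncc1C(OCc1ccc(C#N)cc1-c1ccc(F)c(Cl)c1)c1ccc(C#N)nc1` is one of two compounds measured in an assay on isolated protein (Bos taurus) for inhibition of geranylgeranyl transferase type-1 subunit beta (Homo sapiens); on this read-out higher numbers stand for weaker inhibition and lower numbers for stronger inhibition. In this assay compound 1 gives 8600 nM, the higher of the two numbers, while compound 2 `Cn1cncc1C(OCc1ccc(C#N)cc1)c1ccc(C#N)c(-c2cccc3cccnc23)c1` gives 103 nM, a gap well beyond the usual scatter. Compound 3 `Cn1cncc1C(OCc1ccc(C#N)cc1-c1cc(Cl)cc(Cl)c1)c1ccc(C#N)nc1` differs from compound 1 by 3,5-dichlorophenyl in place of 3-chloro-4-fluorophenyl on an aromatic carbon. Among the compounds with values here, no measured pair shows this exchange, so the expected step of a 1.2-fold lower number from compound 1 to compound 3 (0.09 log units; within the scatter) is small, probably none beyond the scatter. Compound 3 is therefore estimated at 7000 nM, with a range from 2500 nM to 20000 nM.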

Compound 3, half-maximal inhibitory concentration: 960 nM
Beside the measured number, compound 3's estimate is 7.3-fold (0.86 log units) above it; measured number outside the range, below it.
By their numbers in this assay, from the lowest: compound 2; then compound 3; then compound 1.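

The two rings hold the same count of heavy atoms and neither carries a hydrogen-bond donor or acceptor, yet the exchange still gives a 9.0-fold lower number from compound 1 to compound 3 (0.95 log units; beyond the scatter), a step beyond the scatter. This position on the core of compound 1 therefore responds to which halogens its phenyl ring carries and where they sit, even when the ring's size stays the same. Nothing available here explains the size of this step. Because one fluorine is lost and the chlorines change together, the compounds shown cannot separate these two parts of the exchange. They also leave open how this position would respond to a phenyl ring bearing a methoxy group or an amine.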